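Swapping the aryl group on compound 3

The source may hold more compounds than are shown below. What is called first, only, known or untested is meant among the compounds shown, and "the series" means these compounds.

Measured so far in a functional assay on SK-MEL-28 cells (Homo sapiens) for cytotoxicity, read by CCK-8 assay, with a stated time of 24 h; a higher number here means a weaker inhibitor, a lower number a stronger inhibitor
compound 1 `COc1ccccc1Oc1c(N)nc(-c2cccc(C)c2)nc1Cl` gives 54000 nM
compound 2 `COc1ccccc1Oc1c(N)nc(-c2ccc(I)cc2)nc1Cl` gives 1250 nM
compound 3 `COc1ccccc1Oc1c(N)nc(-c2cccc(C)c2)nc1OCCO` gives 14700 nM

Compound 3 sits in the middle of these three, weaker than compound 2 and stronger than compound 1, with both gaps beyond the usual scatter. Compound 4 `COc1ccccc1Oc1c(N)nc(-c2ccc(Cl)cc2)nc1OCCO` keeps the 2-hydroxyethoxy group but carries 4-chlorophenyl in place of 3-methylphenyl (4-chlorophenyl in place of 3-methylphenyl on an aromatic carbon). Among the compounds with values here, the closest precedent is a 43-fold lower number from compound 1 to compound 2 (1.64 log units; beyond the scatter) for a large change, from 3-methylphenyl to 4-iodophenyl. That step, however, involved iodine rather than chlorine and took place with chloro on the core rather than 2-hydroxyethoxy. Within the data shown here, the other, a 3.7-fold lower number from compound 1 to compound 3 (0.57 log units; beyond the scatter) for a modest change, shows only that compound 3 already lies lower than compound 1. A drop is therefore expected, though probably a smaller one than the step to compound 2. In this assay the estimate means a 4.9-fold lower number from compound 3 to compound 4 (0.69 log units; beyond the scatter) as the expected step. Compound 4 is estimated at 3000 nM with an expected range from 700 nM to 10000 nM around that figure.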

Compound 4, half-maximal inhibitory concentration: > 80000 nM
Compound 4: a limit, no number; the forecaster's own chance of this, stated with the estimate: 3%; middle value at least 26-fold (1.42 log units) away from the limit.
By their numbers in this assay, from the lowest: compound 2; then compound 3; then compound 1. At a limit, above all of these: compound 4.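

The aryl position matters with 2-hydroxyethoxy on the core as well, but here the change raises the number: an at least 5.4-fold higher number from compound 3 to compound 4 (0.73 log units; beyond the scatter) in this assay. The reading for compound 4 is a limit of the assay and not a number: the limit of > 80000 nM in this assay, at which 1 of the 4 values shown sits. A halogen at the 4-position of the phenyl group therefore does not always lower the number, since the earlier step to 4-iodophenyl, made with chloro on the core, went the other way: a 43-fold lower number from compound 1 to compound 2 (1.64 log units; beyond the scatter).

Going by these compounds, it remains open whether the opposite directions follow the halogen, iodine against chlorine, or the core group, chloro against 2-hydroxyethoxy. Pairing 4-iodophenyl with 2-hydroxyethoxy and 4-chlorophenyl with chloro would separate the two, and 4-bromophenyl would show how a further halogen behaves at this position.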